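This account rests on a few compounds, and the source may have more. Where it says the series, first, only, none or still open, it means among the compounds named here.

Working notes on the series: in a functional assay on A549 cells (Homo sapiens) for antiproliferative activity, read by MTT assay, with a stated time of 24 h (on this read-out higher numbers stand for weaker inhibition and lower numbers for stronger inhibition), compound 1 `Cc1ccc(/C=N/c2ccccc2)c(C)c1` gives 144000 nM and compound 2 `O=[N+]([O-])c1ccc(/C=N/c2ccccc2)cc1` gives 2000 nM as the lower of the two numbers, with a gap between them that lies beyond the usual scatter. Compound 3 `FC(F)(F)c1ccc(/C=N/c2ccccc2)cc1` carries trifluoromethyl in place of the nitro of compound 2 on an aromatic carbon trifluoromethyl in place of nitro on an aromatic carbon of the shared core. Among the compounds with values here, no measured pair isolates this change, so the expectation rests on two values only. Compound 2 at 2000 nM is the lower of those values, so a move toward weaker inhibition in this assay is the likelier direction, though probably much smaller than the gap to compound 1. The expected change is a 4.0-fold higher number from compound 2 to compound 3 (0.60 log units; beyond the scatter) and would probably lie beyond the scatter. For compound 3 the estimated value is 8000 nM with an expected range from 2500 nM to 30000 nM on this read-out.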

Compound 3, half-maximal inhibitory concentration: 161000 nM
The estimate for compound 3 lay 20-fold (1.30 log units) below the measured number, outside the stated range (above it).
By their numbers in this assay, from the lowest: compound 2; then compounds 1 and 3 (each within the scatter of the next).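

In this assay, within the data shown here, trifluoromethyl in place of nitro on this aromatic carbon, para to a group of 8 heavy atoms, gives an 81-fold higher number from compound 2 to compound 3 (1.91 log units; beyond the scatter), the only step so far that isolates a single change. This position is therefore not indifferent to the group it carries: the low number of compound 2 does not carry over to compound 3, so within this pair it goes with nitro and is lost with trifluoromethyl. Nothing available bears on why these two groups differ so strongly here.

The compounds shown leave open how a nitrile, an amine or a carboxylic acid on the same aromatic carbon would compare with nitro and trifluoromethyl. They also leave open whether this exchange gives a step of similar size at another carbon of the same ring.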